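Swapping a cyanophenyl for a pyrimidinyl on the shared core

A few compounds are considered here, and "the series" means these few. Any claim that something is new, unique, unknown or untested is made for them only; others in the source may bear on it.

Of the compounds shown here, three sharing one core have been measured in a functional assay on CHO-K1 cells for antagonist activity at adenosine receptor A1 (Homo sapiens), read by a beta-galactosidase reporter and cAMP accumulation, with stated times of 15 min and 6 h; a higher number here means a weaker inhibitor, a lower number a stronger inhibitor. Compound 1 `Nc1nc(C2CCCO2)nc2sc(Cc3ccccc3)cc12` gives 2950 nM. Compound 2 `Nc1nc(-c2ccccc2)nc2sc(Cc3ccccc3)cc12` gives 151 nM, and compound 3 `N#Cc1cccc(-c2nc(N)c3cc(Cc4ccccc4)sc3n2)c1` gives 222 nM. Among these three numbers compound 3 stands second highest: its nearest neighbour is compound 2, within the scatter, and its furthest is compound 1, beyond the scatter.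

The step of interest leads to compound 4 `Nc1nc(-c2ncccn2)nc2sc(Cc3ccccc3)cc12`, where (pyrimidin-2-yl in place of 3-cyanophenyl on an aromatic carbon). Among the compounds with values here, two measured steps bear on it. Replacing oxolan-2-yl with an aromatic six-membered ring gave a 20-fold lower number from compound 1 to compound 2 (1.29 log units; beyond the scatter) and a 13-fold lower number from compound 1 to compound 3 (1.12 log units; beyond the scatter), both large. The change of cyano to hydrogen on that ring gave a 1.5-fold higher number from compound 2 to compound 3 (0.17 log units; within the scatter), a step within the scatter. Within the data shown here, compound 4 keeps a six-membered aromatic ring at the same place, so the large gain seen against compound 1 is expected to persist, while no measured compound shows what two ring nitrogens do there.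

The step is therefore expected to be small, as a 1.4-fold higher number from compound 3 to compound 4 (0.13 log units; within the scatter), with a wide range to cover the untested ring. Compound 4 is estimated at 300 nM in this assay, between 80 nM and 1200 nM.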

Compound 4, inhibition constant: 618 nM
Estimate against measurement, compound 4: 2.1-fold (0.31 log units) below; low and high end bracket the measured number.
By their numbers in this assay, from the lowest: compounds 2 and 3 (each within the scatter of the next); then compound 4; then compound 1.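

In this assay the phenyl and 3-cyanophenyl compounds could not be told apart, which left open whether the atoms of the ring at this position matter at all. Compound 4 shows that they do: pyrimidin-2-yl gives a 2.8-fold higher number from compound 3 to compound 4 (0.44 log units; beyond the scatter) and a 4.1-fold higher number from compound 2 to compound 4 (0.61 log units; beyond the scatter), so a six-membered aromatic ring does not by itself preserve the number, and the ring with two nitrogens stands apart from the two rings of carbon only. Part of the gain over oxolan-2-yl remains, as a 4.8-fold lower number from compound 1 to compound 4 (0.68 log units; beyond the scatter), but this modest step is smaller than the large 20-fold lower number from compound 1 to compound 2 (1.29 log units; beyond the scatter), placing pyrimidin-2-yl between the carbon-only rings and the saturated oxolan-2-yl.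

No measurement here explains why the pyrimidin-2-yl compound differs from the carbon-only rings. Also open, from the compounds shown here alone, is whether one ring nitrogen, as in pyridin-2-yl, would give a number nearer compound 2 or compound 4, and whether an amine or a carboxylic acid in place of the nitrile on the phenyl ring would leave the number unchanged.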